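Moving the quinazoline attachment from the 8- to the 5-position

A few compounds are considered here, and "the series" means these few. Any claim that something is new, unique, unknown or untested is made for them only; others in the source may bear on it.

Compound 1: `Cc1cc(F)cnc1N1CCN(C(=O)CCCc2cccc3cncnc23)[C@@H](C)C1`, an ADME assay on microsomes from liver (Rattus norvegicus) for metabolic stability, read by LC-MS, with a stated time of 15 min, tested at 1 uM; a lower number here means that less of the compound is left, a higher number that more of the compound is left "not determined" (no result reported)
Compound 2: `Cc1cncc(Cl)c1N1CCN(C(=O)CCS(=O)(=O)c2cccc3ncsc23)CC1`, "not determined" (no result reported)
Compound 3: `O=C(CCS(=O)(=O)c1cccc2ncsc12)N1CCN(c2ccc(Cl)cn2)CC1`, 31%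

Compound 1 stands with no number at all in this assay; compound 2 likewise carries none, so only compound 3 shows a measured result. Compound 4, `Cc1cc(F)cnc1N1CCN(C(=O)CCCc2cccc3ncncc23)[C@@H](C)C1`, differs from compound 1 by quinazolin-5-yl in place of quinazolin-8-yl on a saturated chain carbon, three bonds along the chain from a carbonyl carbon. Since neither compound 1 nor any pair of measured compounds gives a step for this change, the size expected in this assay can only be stated loosely: a shift within the scatter, in no set direction, seems as likely as any other. With only compound 3 as a reference point in this assay, compound 4 is estimated at 35%, expected to fall between 10% and 70%.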

Compound 4, percent of the compound remaining: 0%
Estimate against measurement, compound 4: 35 percentage points above, outside the stated range (below it).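

No step can be read from compound 1 to compound 4: in this assay compound 1 gives "not determined" (no result reported), while compound 4 gives 0%. The compounds shown leave open how quinazolin-5-yl compares with quinazolin-8-yl on this chain. No supporting data bear on the result of compound 4.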